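This account rests on a few compounds, and the source may have more. Where it says the series, first, only, none or still open, it means among the compounds named here.

Measured in a functional assay (muscle tissue) with Cavia porcellus as the target; on this read-out higher numbers stand for an effect only at larger amounts of compound and lower numbers for an effect already at smaller amounts:
- compound 1 `COC(=O)C1=C(C)N=C(C)/C(=C(\O)OC)C1c1ccccc1OC`: 57.5 nM
- compound 2 `COC(=O)C1=C(C)N=C(C)/C(=C(\O)OC)C1c1cccc(Cl)c1Cl`: 19.1 nM
- compound 3 `COC(=O)C1=C(C)N=C(C)/C(=C(\O)OC)C1c1cccc(I)c1`: 41.7 nM

Compound 3 lies within the scatter of compound 1, as a 1.4-fold lower number from compound 1 to compound 3 (0.14 log units; within the scatter) shows, while a 2.2-fold higher number from compound 2 to compound 3 (0.34 log units; beyond the scatter) separates it from compound 2. Compound 4 `COC(=O)C1=C(C)N=C(C)/C(=C(\O)OC)C1c1cccc(F)c1` has fluoro in place of iodo on an aromatic carbon. For the measured compounds named here, no measured step makes this exchange directly. The nearest evidence is the change of phenyl substituents, which gave a 3.0-fold lower number from compound 1 to compound 2 (0.48 log units; beyond the scatter) at its largest, a modest size. On that evidence, no change beyond the scatter is expected in this assay. The expected change is a 1.0-fold lower number from compound 3 to compound 4 (0.02 log units; within the scatter). For compound 4 the estimate is 40 nM, with an expected range of 13 nM to 120 nM.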

Compound 4, half-maximal effective concentration: 20.9 nM
Estimate against measurement, compound 4: 1.9-fold (0.28 log units) above; the range from low to high includes it.
By their numbers in this assay, from the lowest: compounds 2, 4, 3 and 1 (each within the scatter of the next, the first and the last beyond it).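

In this assay, the exchange of iodo for fluoro at this place stays within the scatter, with a 2.0-fold lower number from compound 3 to compound 4 (0.30 log units; within the scatter), so the two halogens cannot be told apart here. The 3-fluorophenyl group also stays within the scatter of the 2,3-dichlorophenyl group, with a 1.1-fold higher number from compound 2 to compound 4 (0.04 log units; within the scatter), and, unlike 3-iodophenyl, it moves beyond the scatter from 2-methoxyphenyl, with a 2.8-fold lower number from compound 1 to compound 4 (0.44 log units; beyond the scatter). Nothing measured here explains these steps.

Still open, on these data alone, is how an amine or a carboxylic acid would fare at this place on the aromatic ring. The compounds shown also leave open whether chloro or bromo alone would fall within the same scatter.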